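The source may report more compounds than this note shows. Statements on the series, on what has been measured and on what is new or still open speak of the compounds shown alone.

Measured compounds:
compound 1 `Cc1cc(F)cc(C)c1Oc1ccc(C(C)(C)O)cc1-c1cn(C)c(=O)c2[nH]c(C(=O)NCc3ccc(C(=O)NO)cc3)cc12` gives 39.3 nM
compound 2 `Cn1cc(-c2ccccc2Oc2ccccc2)c2cc(C(=O)NCc3ccc(C(=O)NO)cc3)[nH]c2c1=O` gives 15.3 nM
compound 3 `Cn1cc(-c2ccccc2Oc2ccccc2)c2cc(C(=O)NCCCCCC(=O)Nc3ccccc3N)[nH]c2c1=O` gives > 500 nM

In an assay on isolated protein for inhibition of protein deacetylase HDAC6 (Homo sapiens), read by fluorescence (a lower number here means a stronger inhibitor, a higher number a weaker inhibitor), compound 1 stands highest of the two numbers shown. Its nearest neighbour is compound 2, which gives a lower number, and that gap lies beyond the usual scatter of this assay. For compound 3 the assay reports only a limit, (the limit of > 500 nM in this assay, at which 1 of the 3 values shown sits), and no number.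

The step from compound 1 to compound 4 `CC(C)Oc1ccc(C(C)(C)O)cc1-c1cn(C)c(=O)c2[nH]c(C(=O)NCc3ccc(C(=O)NO)cc3)cc12` keeps the shared core and the whole benzylic hydroxamate arm and alters only the ether substituent: isopropyl in place of 4-fluoro-2,6-dimethylphenyl on an oxygen on an aromatic ring. Among the measured compounds shown here, compound 2 shows that a smaller aryl ether on the same oxygen gives a lower number than compound 1, but no measured pair tells how a non-aromatic group on that oxygen behaves, so the direction of this change is not fixed by the data.

Compound 4 is expected to sit near compound 1, with a step of a 1.1-fold higher number from compound 1 to compound 4 (0.06 log units; within the scatter) in this assay. The estimate for compound 4 is 45 nM, with a range from 15 nM to 135 nM.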

Compound 4, half-maximal inhibitory concentration: 52 nM
Compound 4: the middle estimate sits 1.2-fold (0.06 log units) below what was measured, within the range that was stated.
By their numbers in this assay, from the lowest: compound 2; then compounds 1 and 4 (each within the scatter of the next). At a limit, above all of these: compound 3.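

Going from the aryl ether to the alkyl ether, this assay records a 1.3-fold higher number from compound 1 to compound 4 (0.12 log units; within the scatter). Among the compounds shown here, this is the first measured pair to speak to a non-aromatic group on this oxygen, and it shows that, with the shared core and the benzylic hydroxamate arm kept, 4-fluoro-2,6-dimethylphenyl can give way to isopropyl without a step beyond the scatter. The aromatic ring and the fluorine that leave with it are therefore not needed at this position to hold a number of this size, although nothing shown gives a cause for this result.

The compounds shown leave open how a methyl group, a longer alkyl chain or a chain ending in an amine would read on this oxygen. This single pair also cannot tell whether the same change would behave alike without the 2-hydroxypropan-2-yl group on the shared core.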